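The source may report more compounds than this note shows. Statements on the series, on what has been measured and on what is new or still open speak of the compounds shown alone.

Compound 1 `Cn1cncc1CN1CC(N(CC2CCN(C(=O)c3ccc(Cl)cc3)CC2)S(=O)(=O)c2ccccn2)Cc2cc(C#N)ccc21`: 0.5 10^-6 cm/s
Compound 2 `Cn1cncc1CN1CC(N(CC2CCN(C(=O)c3ccco3)CC2)S(=O)(=O)c2ccccn2)Cc2cc(C#N)ccc21`: 0.5 10^-6 cm/s
Compound 3 `Cn1cncc1CN1CC(N(Cc2ccc(S(C)(=O)=O)cc2)S(=O)(=O)c2ccccn2)Cc2cc(C#N)ccc21`: 0.2 10^-6 cm/s

In an ADME assay on Caco-2 cells (Homo sapiens) for permeability, in the apical to basolateral direction (a higher number here means that the compound crosses the layer faster, a lower number that the compound crosses the layer more slowly), compound 3 gives 0.2 10^-6 cm/s, the lowest of the three numbers. Compound 1 gives 0.5 10^-6 cm/s and compound 2 gives 0.5 10^-6 cm/s, and each of these lies above compound 3 by a margin beyond the usual scatter of repeated measurements.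

Compound 4 `CCS(=O)(=O)N1CCC(CN(C2Cc3cc(C#N)ccc3N(Cc3cncn3C)C2)S(=O)(=O)c2ccccn2)CC1` differs from compound 3 in one place: 1-(ethylsulfonyl)piperidin-4-yl in place of 4-(methylsulfonyl)phenyl on a saturated chain carbon bound to a sulfonamide nitrogen. Within the data shown here, the only measured step in this set, no change at the digits printed from compound 1 to compound 2 (within the scatter), concerns a group on a carbonyl carbon and leaves untouched the part of the molecule that changes here, so no measured step speaks directly to the move from compound 3 to compound 4. What the numbers do show is that compounds 1 and 2, whose structures stand above, both cross the cell layer faster than compound 3. That leaves the direction of the step open but sets the likely range: compound 4 is expected to come out close to compound 3 or modestly higher, a step of a 2.0-fold higher number from compound 3 to compound 4 (0.30 log units; within the scatter). The estimate for compound 4 in this assay is 0.4 10^-6 cm/s, with a range from 0.2 10^-6 cm/s to 0.9 10^-6 cm/s.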

Compound 4, apparent permeability: 0.1 10^-6 cm/s
Compound 4: the middle estimate sits 4.0-fold (0.60 log units) above what was measured; the whole stated range lies above it.
By their numbers in this assay, from the lowest: compounds 4 and 3 (each within the scatter of the next); then compounds 1 and 2 (each within the scatter of the next).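

In this assay, replacing 4-(methylsulfonyl)phenyl with 1-(ethylsulfonyl)piperidin-4-yl on a saturated chain carbon bound to a sulfonamide nitrogen gives a 2.0-fold lower number from compound 3 to compound 4 (0.30 log units; within the scatter), so exchanging a six-membered aromatic ring of carbon only for a six-membered non-aromatic ring with 1 hetero atom does not separate these two compounds. The group on the amine nitrogen in the ring now shows a measurable effect: ethylsulfonyl in place of (furan-2-yl)carbonyl gives a 5.0-fold lower number from compound 2 to compound 4 (0.70 log units; beyond the scatter) and ethylsulfonyl in place of (4-chlorophenyl)carbonyl gives a 5.0-fold lower number from compound 1 to compound 4 (0.70 log units; beyond the scatter), whereas the two carbonyl groups could not be told apart. No measurement shown here bears on the reason for these steps.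

From the compounds shown here alone, whether the same steps would appear with a plain methyl or a longer alkyl chain on that ring nitrogen, or with that nitrogen left as a free amine, remains open. Going by these compounds, it is also open whether a carboxylic acid or an amine in place of the methylsulfonyl group on the phenyl ring would move the number in this assay at all.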